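The source may hold more compounds than are shown below. What is called first, only, known or untested is meant among the compounds shown, and "the series" means these compounds.

Measured so far:
compound 1 `CCn1ccc2cc(-c3ccc4oc(NC5CCCCC5)nc4c3)ccc21`, 207 nM
compound 2 `Cn1ncc2cc(-c3ccc4oc(NC5CCCCC5)nc4c3)ccc21`, 61 nM
compound 3 `CN(c1ccccc1)c1nc2cc(-c3ccc4c(ccn4C)c3)ccc2o1`, 68 nM

All three numbers come from an assay on HEK293 cells for inhibition of Fatty-acid amide hydrolase 1 (Homo sapiens), read by fluorescence; a lower number here means a stronger inhibitor, a higher number a weaker inhibitor. Compound 3 gives 68 nM and stands second highest of the three; compound 2, with 61 nM, lies within the scatter of it, while compound 1, with 207 nM, gives the highest number, beyond the scatter from compound 3. Within the data shown here, no pair of measured compounds differs in one place only, so no single step has been measured.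

Compound 4 `Cn1ccc2cc(-c3ccc4oc(N5Cc6ccncc6C5)nc4c3)ccc21` has not been measured in this assay. It differs from compound 3 by a group of 9 heavy atoms (7 carbon, 2 nitrogen; one five-membered non-aromatic ring with 1 hetero atom, one six-membered aromatic ring with 1 hetero atom) in place of a group of 8 heavy atoms (7 carbon, 1 nitrogen; one six-membered aromatic ring of carbon only), on an aromatic carbon. Among the measured compounds shown here, nothing among the measured compounds shows a change of this kind at the aromatic carbon of the five-membered ring, so there is no measured step to lean on. The expectation for the step from compound 3 to compound 4 is therefore set near no change beyond the scatter, with wide bounds: the step is estimated as a 1.6-fold higher number from compound 3 to compound 4 (0.21 log units; within the scatter). For compound 4 the expected value in this assay is 110 nM, in the range 30 nM to 450 nM.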

Compound 4, half-maximal inhibitory concentration: 121 nM
The estimate for compound 4 lay 1.1-fold (0.04 log units) below the measured number; the range from low to high includes it.
By their numbers in this assay, from the lowest: compounds 2, 3, 4 and 1 (each within the scatter of the next, the first and the last beyond it).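

Among these compounds, at the aromatic carbon of the five-membered aromatic ring with 1 nitrogen and 1 oxygen, the first step that can be read in this assay is a 1.8-fold higher number from compound 3 to compound 4 (0.25 log units; within the scatter), and it lies within the scatter. Methyl(phenyl)amino and the entering group, with its five-membered non-aromatic ring and six-membered aromatic ring with 1 hetero atom, are therefore not told apart here, although the change removes a six-membered aromatic ring of carbon only and goes from 1 hydrogen-bond acceptor to 2. No measured property bears on this result.

Open, from the compounds shown here alone, is whether cyclohexylamino, a small amine such as dimethylamino, or a carboxylic acid at this position would move the number beyond the scatter. Compound 1 and compound 2 differ from compound 3 in more than one place, so they cannot settle this.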